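Moving the bromine: from compound 1 to compound 4

This account rests on a few compounds, and the source may have more. Where it says the series, first, only, none or still open, it means among the compounds named here.

Measured so far in a functional assay on MCF7 cells (Homo sapiens) for antiproliferative activity, read by MTT assay, with a stated time of 48 h; a higher number here means a weaker inhibitor, a lower number a stronger inhibitor (lower means stronger):
compound 1 `N=C(N)N/N=C(/C=C/c1ccc(Br)cc1)c1ccccc1` gives 250 nM
compound 2 `N=C(N)N/N=C(/C=C/c1ccc(OCc2ccccc2)cc1)c1ccccc1` gives 1200 nM
compound 3 `COc1cccc(/C=C/C(=N/NC(=N)N)c2ccccc2)c1` gives 13000 nM

Compound 1 holds the lowest of the three numbers, and both other compounds lie beyond the scatter from it. The next compound is compound 4 `N=C(N)N/N=C(/C=C/c1ccccc1Br)c1ccccc1` and the change is 2-bromophenyl in place of 4-bromophenyl on a double-bonded chain carbon bound to a double-bonded chain carbon with the same atoms joined differently. For the measured compounds named here, the only measured step in one place is a 4.8-fold higher number from compound 1 to compound 2 (0.68 log units; beyond the scatter) and it replaces the bromo group instead of moving it, so it bears on this change only loosely. Compound 3 at 13000 nM shows a much higher number than compound 1 does. Going by the values given here, no measured pair isolates a move of one group on this ring. Among the compounds with values here, a change of modest size towards a higher number is therefore expected in this assay with a wide margin, guided by a 4.8-fold higher number from compound 1 to compound 2 (0.68 log units; beyond the scatter) as the only measured step. The estimated change is a 3.2-fold higher number from compound 1 to compound 4 (0.51 log units; beyond the scatter) and it remains an expectation. The estimated value for compound 4 is 800 nM (expected range 150 nM to 5000 nM).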

Compound 4, half-maximal inhibitory concentration: 4200 nM
Compound 4: middle estimate off by 5.3-fold (0.72 log units), on the low side; low and high end bracket the measured number.
By their numbers in this assay, from the lowest: compound 1; then compound 2; then compound 4; then compound 3.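

In this assay, moving the bromine with no change in the atoms of the group gives a 17-fold higher number from compound 1 to compound 4 (1.23 log units; beyond the scatter), so where the bromine sits on this ring matters in its own right. That step is larger than the outright replacement of the bromo group by benzyloxy, a 4.8-fold higher number from compound 1 to compound 2 (0.68 log units; beyond the scatter), so for this pair, 2-bromophenyl in place of 4-bromophenyl weighs more than that change of group. Nothing measured here explains why the number rises with this move.

The compounds shown leave open whether another group on this ring, such as a chlorine or an amine, responds to the same move as the bromine does. Only one such move is on hand, so the finding holds for compound 1 and compound 4 alone.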